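The source may hold more compounds than are shown below. What is called first, only, known or untested is meant among the compounds shown, and "the series" means these compounds.

Compound 3 `C=C(C)CCOC(=O)C1=C(C)NC(C)=C(C(=O)OC)C1c1cccc([N+](=O)[O-])c1` gives 47 nM in a functional assay on HEK293 cells for antagonist activity at Voltage-dependent L-type calcium channel subunit alpha-1D (Rattus norvegicus), read by FLIPR; a higher number here means a weaker inhibitor, a lower number a stronger inhibitor. Compound 1 `CCOC(=O)C1=C(C)NC(CCl)=C(C(=O)OCC)C1c1cccc([N+](=O)[O-])c1` gives 53 nM, a number within the usual scatter of compound 3, while compound 2 `CCOC(=O)C1=C(C)NC(C(OCC)OCC)=C(C(=O)OCC)C1c1cccc([N+](=O)[O-])c1` gives 615 nM, far weaker than either. Among the compounds with values here, the only single-point step measured is a 12-fold higher number from compound 1 to compound 2 (1.06 log units; beyond the scatter), which concerns a double-bonded ring carbon and not the ester chain. Compound 4 `COC(=O)C1=C(C)NC(C)=C(C(=O)OCc2ccc(-c3ccccc3)cc2)C1c1cccc([N+](=O)[O-])c1` differs from compound 3 by 4-phenylphenyl in place of 2-methylprop-2-en-1-yl on a saturated chain carbon bound to an oxygen next to a carbonyl group. Within the data shown here, no measured step touches that ester position, so the record offers no direct guide to the direction or size of the change. Compound 4 is therefore expected to stay close to compound 3, with a step of a 1.5-fold higher number from compound 3 to compound 4 (0.17 log units; within the scatter) in this assay, and its estimated value is 70 nM (range 15 nM to 300 nM).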

Compound 4, half-maximal inhibitory concentration: 74 nM
Compound 4: the middle estimate sits 1.1-fold (0.02 log units) below what was measured; the range from low to high includes it.
By their numbers in this assay, from the lowest: compounds 3, 1 and 4 (each within the scatter of the next); then compound 2.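

In this assay, within the data shown here, the one measured change at the saturated chain carbon bound to an oxygen next to a carbonyl group gives a 1.6-fold higher number from compound 3 to compound 4 (0.20 log units; within the scatter) and so stays within the scatter. Replacing 2-methylprop-2-en-1-yl, with 4 heavy atoms and no ring, by 4-phenylphenyl, with 12 heavy atoms and 2 aromatic rings, therefore brought no detectable loss in this pair. No independent evidence bears on this result. On these data alone, whether a chain ending in an amine or a carboxylic acid at this place would behave the same remains open.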